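The source may hold more compounds than are shown below. What is called first, only, known or untested is meant among the compounds shown, and "the series" means these compounds.

Working notes on the series.

Of the compounds shown here, three of the shared core have been measured. Compound 1 `O=C(CCCCC1CCSS1)NCc1cn(CCCOc2ccc3ccc(=O)oc3c2)nn1` gives, in a functional assay on PC-12 cells (Rattus norvegicus) for cytotoxicity, read by MTT assay, with stated times of 3 h and 2 h, tested at 5 uM (a lower number here means a weaker effect, a higher number a stronger effect of the compound at the concentration tested), 39.2%. Compound 2 `CC(=O)c1cc2ccc(OCCCn3cc(CNC(=O)CCCCC4CCSS4)nn3)cc2oc1=O` gives in this assay 37.5%, and the step of a number 1.7 percentage points lower from compound 1 to compound 2 (within the scatter) is within the scatter. Compound 3 `COc1ccc(-c2cc3ccc(OCCCn4cc(CNC(=O)CCCCC5CCSS5)nn4)cc3oc2=O)cc1` gives in this assay 52.8%, the highest of the three numbers; its steps of a number 13.6 percentage points higher from compound 1 to compound 3 (beyond the scatter) and a number 15.3 percentage points higher from compound 2 to compound 3 (beyond the scatter) both lie beyond the scatter, so compound 3 stands apart from compound 1 and compound 2 in this assay.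

Compound 4 `O=C(CCCCC1CCSS1)NCc1cn(CCCOc2ccc3cc(-c4ccc(Br)cc4)c(=O)oc3c2)nn1` is not yet measured. It differs from compound 3 in one place: bromo in place of methoxy on an aromatic carbon. Within the data shown here, none of the measured steps touches this position; the steps from compound 1 and compound 2 to compound 3 concern the carbon on which the 4-methoxyphenyl itself enters, and both were modest. Among the measured compounds shown here, no measured pair shows what exchanging methoxy for bromo on that pendant phenyl does, so a step within the scatter is the plainest expectation, with a wide range allowed either way.

Compound 4 is therefore expected to give 50% in this assay, within a range of 38% to 62%. The expected step of a number 2.8 percentage points lower from compound 3 to compound 4 (within the scatter) is estimated to be within the scatter.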

Compound 4, a percentage reported as activity, at one concentration (the size of the read-out at that concentration, not a potency): 57.3%
Compound 4: middle estimate off by 7.3 percentage points, on the low side, and the stated range covers the measured number.
By their numbers in this assay, from the lowest: compounds 2 and 1 (each within the scatter of the next); then compounds 3 and 4 (each within the scatter of the next).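

On the pendant phenyl, on an aromatic carbon para to a large group, bromo in place of methoxy gives a number 4.5 percentage points higher from compound 3 to compound 4 (within the scatter) in this assay, so this exchange does not separate the two compounds and this position tolerates either group here. The separation of compound 3 from compounds 1 and 2 is also not confined to the 4-methoxyphenyl: the 4-bromophenyl gives a number 19.8 percentage points higher from compound 2 to compound 4 (beyond the scatter) and a number 18.1 percentage points higher from compound 1 to compound 4 (beyond the scatter), both steps beyond the scatter and both in the same direction as those of the 4-methoxyphenyl, a pattern that rests on these four compounds alone. Nothing available explains these numbers, so the reason for them remains unknown.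

Still open, going by these compounds, is whether other groups in this place, such as an amine, a carboxylic acid or a hydrogen that leaves a plain phenyl, would stay with compounds 3 and 4 or fall back towards compounds 1 and 2. Since the read-out comes from a single concentration, the compounds shown also leave open how these differences would look at other concentrations.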